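Aryl amine variation on the acetylated core

The source may report more compounds than this note shows. Statements on the series, on what has been measured and on what is new or still open speak of the compounds shown alone.

Compound 1 `C=C1[C@@H](OC(C)=O)C[C@@H]2[C@](C)(CO[Si](C)(C)C(C)(C)C)[C@H](OC(C)=O)CC[C@@]2(C)[C@@H]1C[C@@H](Nc1cccc(F)c1)C1=CCOC1=O` and compound 2 `C=C1[C@@H](OC(C)=O)C[C@@H]2[C@](C)(CO[Si](C)(C)C(C)(C)C)[C@H](OC(C)=O)CC[C@@]2(C)[C@@H]1C[C@@H](Nc1cccc2ccccc12)C1=CCOC1=O` share the same core and differ only at the amine nitrogen. Going by the values given here, in a functional assay on HT-29 cells (Homo sapiens) for cytotoxicity, read by sulforhodamine B assay (a higher number here means a weaker inhibitor, a lower number a stronger inhibitor), compound 1 gives 4520 nM, and compound 2 gives 15000 nM, the highest number of the pair; the only measured step is a 3.3-fold higher number from compound 1 to compound 2 (0.52 log units; beyond the scatter). Compound 3 `C=C1[C@@H](OC(C)=O)C[C@@H]2[C@](C)(CO[Si](C)(C)C(C)(C)C)[C@H](OC(C)=O)CC[C@@]2(C)[C@@H]1C[C@@H](Nc1ccc(F)cc1)C1=CCOC1=O` differs from compound 2 by 4-fluorophenyl in place of naphthalen-1-yl on an amine nitrogen. Among the compounds with values here, this returns to a single fluorinated ring as in compound 1, so the step is expected to reverse the one seen from compound 1 to compound 2, giving an estimated 3.0-fold lower number from compound 2 to compound 3 (0.48 log units; beyond the scatter). Compound 3 is expected at 5000 nM, within 2000 nM to 12000 nM.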

Compound 3, half-maximal inhibitory concentration: 4940 nM
For compound 3 the middle estimate is 1.0-fold (0.01 log units) above the measured one; the range from low to high includes it.
By their numbers in this assay, from the lowest: compounds 1 and 3 (each within the scatter of the next); then compound 2.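

In this assay the fluorine's place on the phenyl ring makes no readable difference, with a 1.1-fold higher number from compound 1 to compound 3 (0.04 log units; within the scatter) for 4-fluorophenyl against 3-fluorophenyl on the amine nitrogen. The naphthalen-1-yl group of compound 2 now stands apart from two fluorophenyl compounds rather than one, with a 3.0-fold lower number from compound 2 to compound 3 (0.48 log units; beyond the scatter) as the second step. No measurement offered here explains either step.

From the compounds shown here alone, whether fluorine contributes at all remains open, and an unsubstituted phenyl on the amine nitrogen would address that. Also open, going by these compounds, is whether naphthalen-2-yl would behave like naphthalen-1-yl.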